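Chloro in place of methyl: expectation for compound 3

The source may report more compounds than this note shows. Statements on the series, on what has been measured and on what is new or still open speak of the compounds shown alone.

Measured compounds:
compound 1 `COc1cc2oc(-c3ccc(NC(=O)c4ccc(Cl)cc4)cc3)cc(=O)c2c(OC)c1OC`: <= 42.6% (a limit of the assay)
compound 2 `COc1cc2oc(-c3cccc(C(=O)Nc4ccc(C)cc4)c3)cc(=O)c2c(OC)c1OC`: 82.6%

Going by the values given here, in a functional assay on RPMI-8226 cells (Homo sapiens) for inhibition, read by sulforhodamine B assay, tested at 10 uM (on this read-out higher numbers stand for more inhibition at the one concentration tested (going by the name of the read-out) and lower numbers for less inhibition), compound 2 gives 82.6%, the only plain number among the two measured compounds. Compound 1 returns only a limit of the assay, <= 42.6%; this is the limit of <= 42.6% in this assay, at which 1 of the 2 values shown sits. Among the compounds with values here, no step between measured compounds can be drawn, so compound 2 stands alone as the reference point with a full number.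

Compound 3 `COc1cc2oc(-c3cccc(C(=O)Nc4ccc(Cl)cc4)c3)cc(=O)c2c(OC)c1OC` differs from compound 2 by chloro in place of methyl on an aromatic carbon. Within the data shown here, with no measured step of this kind available, the step of a number 10.6 percentage points lower from compound 2 to compound 3 (beyond the scatter) is expected to be modest, probably downward but possibly within the scatter. Compound 3 is therefore estimated at 72%, with a range from 45% to 90%, some chance remaining that only a limit is reported.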

Compound 3, a percentage reported as inhibition, at one concentration (the size of the read-out at that concentration, not a potency): 82.6%
Compound 3: middle estimate off by 10.6 percentage points, on the low side, and the stated range covers the measured number.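

In this assay, going by these compounds alone, the change of chloro in place of methyl on an aromatic carbon, para to a large group, gives no change at the digits printed from compound 2 to compound 3 (within the scatter) and so supplies the first step that can be read between two plain numbers. At this position, 4-methylphenyl and 4-chlorophenyl on the carbamoyl group therefore cannot be told apart in this read-out at the one concentration tested. No measured property among the data shown bears on this result.

As far as these compounds go, what an amine or a carboxylic acid would give at this same place remains open. Also open, from the compounds shown here alone, is whether compound 2 and compound 3 would still read alike at lower concentrations, since a single-concentration percentage is not a potency.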